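Swapping the aryl group on compound 3's ring nitrogen

A few compounds are considered here, and "the series" means these few. Any claim that something is new, unique, unknown or untested is made for them only; others in the source may bear on it.

Three ureas sharing one core have been measured in a functional assay on NCI-H1581 cells (Homo sapiens) for inhibition, read by MTT assay, with a stated time of 48 h, tested at 10 uM; on this read-out higher numbers stand for more inhibition at the one concentration tested (going by the name of the read-out) and lower numbers for less inhibition. Compound 1 `COc1cc(NC(=O)Nc2cc(Nc3cc(Br)ccc3OC)ncn2)cc(OC)c1` gives 23.1%, compound 2 `CCc1cccc(Nc2cc(NC(=O)Nc3cc(OC)cc(OC)c3)ncn2)c1` gives 27.7%, and compound 3 `COc1cc(NC(=O)Nc2cc(Nc3ccc(F)c(Cl)c3)ncn2)cc(OC)c1` gives 53%, the highest of the three; the steps of a number 29.9 percentage points higher from compound 1 to compound 3 (beyond the scatter) and a number 25.3 percentage points higher from compound 2 to compound 3 (beyond the scatter) both lie beyond the scatter, while a number 4.6 percentage points higher from compound 1 to compound 2 (within the scatter) does not. Compound 4 `COc1cc(NC(=O)Nc2cc(Nc3ccc(C(C)(C)C)cc3)ncn2)cc(OC)c1` differs from compound 3 in one place: 4-(tert-butyl)phenyl in place of 3-chloro-4-fluorophenyl on a nitrogen on an aromatic ring. The step from compound 2 to compound 3, which exchanged 3-ethylphenyl for 3-chloro-4-fluorophenyl, bears most directly, and the present change runs the other way, back to a phenyl carrying only a carbon substituent. A drop is therefore expected, a number 23 percentage points lower from compound 3 to compound 4 (beyond the scatter). Compound 4 is estimated at 30%, within 10% to 55%.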

Compound 4, a percentage reported as inhibition, at one concentration (the size of the read-out at that concentration, not a potency): 38.7%
Estimate against measurement, compound 4: 8.7 percentage points below, and the stated range covers the measured number.
By their numbers in this assay, from the lowest: compounds 1 and 2 (each within the scatter of the next); then compound 4; then compound 3.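

A carbon-only substituent at this position does not settle the number at a low level: 4-(tert-butyl)phenyl in compound 4 gives a number 11 percentage points higher from compound 2 to compound 4 (beyond the scatter) and also a number 15.6 percentage points higher from compound 1 to compound 4 (beyond the scatter). It still does not match 3-chloro-4-fluorophenyl, with a number 14.3 percentage points lower from compound 3 to compound 4 (beyond the scatter), so compound 4 falls in a middle place among these four aryl groups on the nitrogen. Nothing available here accounts for this order. Still open, from the compounds shown here alone, is whether chlorine alone or fluorine alone on the phenyl ring would keep the number of compound 3. Also open, going by these compounds, is how an amine or a carboxylic acid on that ring would compare.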